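The source may report more compounds than this note shows. Statements on the series, on what has been measured and on what is new or still open speak of the compounds shown alone.

Compound 1: `COC(=O)N[C@H]1Cc2ccc(NC(=O)c3cc(C(F)(F)F)ccc3-c3ccc(C(F)(F)F)cc3)cc2C1` — 7.5 nM
Compound 2: `COc1cccc(C(=O)Nc2ccc3c(c2)CC(NS(=O)(=O)c2ccccc2)C3)c1-c1ccc(Cl)cc1` — 2 nM
Compound 3: `Cc1cccc(C(=O)Nc2ccc3c(c2)CC(NS(C)(=O)=O)C3)c1-c1ccc(Cl)cc1` — 6.6 nM

All three were measured in an assay for inhibition of apolipoprotein B-100 (Homo sapiens), tested at 100 nM; on this read-out higher numbers stand for weaker inhibition and lower numbers for stronger inhibition. Compound 3 has the second highest of the three numbers; its nearest neighbour is compound 1, whose number lies within the scatter of it, while compound 2 shows a lower number that lies beyond the scatter. Compound 4, `COC(=O)NCC1Cc2ccc(NC(=O)c3cccc(C)c3-c3ccc(Cl)cc3)cc2C1`, differs from compound 3 by ((methoxycarbonyl)amino)methyl in place of methanesulfonamido on a saturated ring carbon. Among the compounds with values here, no step between measured compounds matches this change, so the expectation rests on compound 3 alone. In this assay the step from compound 3 to compound 4 is expected to be small, a 1.4-fold higher number from compound 3 to compound 4 (0.13 log units; within the scatter), with no clear direction beyond the scatter. Compound 4 is therefore estimated at 9 nM, within a range from 3 nM to 30 nM.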

Compound 4, half-maximal inhibitory concentration: 8.7 nM
Compound 4: middle estimate off by 1.0-fold (0.01 log units), on the high side, within the range that was stated.
By their numbers in this assay, from the lowest: compound 2; then compounds 3, 1 and 4 (each within the scatter of the next).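

In this assay, ((methoxycarbonyl)amino)methyl in place of methanesulfonamido on a saturated ring carbon gives a 1.3-fold higher number from compound 3 to compound 4 (0.12 log units; within the scatter), the only step at this position among the compounds shown. The read-out therefore does not separate these two groups, which have the same counts of hydrogen-bond donors and acceptors, on this shared core. Nothing measured here bears on why they read alike.

As far as these compounds go, it remains open whether an amine or a carboxylic acid on this carbon would read the same. From the compounds shown here alone, a longer chain there is equally open.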